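Series notes: sulfur-linked arylalkyl groups on a shared core

The compounds below may be only part of what the source reports. "The series", "measured", "known", "first", "only" and "open" are said of these compounds alone.

Measured compounds:
compound 1, `O=c1c2cn(C3COC3)nc2nc(SCc2cccc(F)c2)n1-c1ccccc1` — 50%
compound 2, `Cn1ncc2c(=O)n(-c3ccccc3)c(SCc3cccc(F)c3)cc21` — 3%
compound 3, `Cn1ncc2c(=O)n(-c3ccccc3)c(SCc3cccc(F)c3)nc21` — 3%

All three were tested in an assay on PEO1 cells for inhibition of Retinaldehyde dehydrogenase 3 (Homo sapiens), read by flow cytometry, with a stated time of 30 min, tested at 1 uM; a higher number here means more inhibition at the concentration tested (going by the name of the read-out), a lower number less inhibition. Compound 3 stands level with compound 2 at the digits reported, and the two together give the lowest numbers of the three; the gap between compound 3 and compound 2 lies within the scatter, so no order between them is claimed. Compound 1 lies well above compound 3, beyond the scatter.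

Compound 4, `C[C@H](Sc1nc2c(cnn2C)c(=O)n1-c1ccccc1)c1ccccc1`, has not yet been measured. It differs from compound 3 in one place: 1-phenylethyl in place of 3-fluorobenzyl on a sulfur. For the measured compounds named here, no measured pair shows this change, so its size cannot be read from the data. The value of compound 3 already sits near the bottom of the range, which leaves little room downward. The step from compound 3 to compound 4 is expected to be a number 5 percentage points higher from compound 3 to compound 4 (within the scatter), not beyond the scatter. In this assay compound 4 is therefore estimated at 8%, with a range from 0% to 30%.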

Compound 4, a percentage reported as inhibition, at one concentration (the size of the read-out at that concentration, not a potency): 2%
For compound 4 the middle estimate is 6 percentage points above the measured one, within the range that was stated.
By their numbers in this assay, from the lowest: compounds 4, 2 and 3 (each within the scatter of the next); then compound 1.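

In this assay, 1-phenylethyl in place of 3-fluorobenzyl on a sulfur gives a number 1 percentage points lower from compound 3 to compound 4 (within the scatter). On this core, the sulfur substituent can therefore lose the fluorine and gain a defined stereocentre with no change that can be told from scatter, though both readings sit so near the bottom of the scale that a further loss would hardly register. Nothing available bears on why the two groups read alike.

Going by these compounds, it remains open whether the same exchange stays as small on the core of compound 1, which gives 50%, where a fall would have room to show. Also open, on these data alone, are how the opposite stereoisomer of 1-phenylethyl reads and whether a sulfur substituent carrying an amine, a carboxylic acid or a longer chain lifts the reading on the core of compound 3.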